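Indazole to Indole: Expected Microsomal Clearance of Compound 4

The compounds below may be only part of what the source reports. "The series", "measured", "known", "first", "only" and "open" are said of these compounds alone.

Measured so far:
compound 1 `COc1cc(N2CCN(C(=O)Cn3ncc4ccccc43)CC2)ccc1-c1cnc(C)o1` – 77 mL.min-1.g-1
compound 2 `COc1cc(N2CCN(C(=O)Cn3cnc4cccc(C(F)(F)F)c43)CC2)ccc1-c1cnc(C)o1` – 7 mL.min-1.g-1
compound 3 `COc1cc(N2CCN(C(=O)N[C@@H](C)c3cccc4ccccc34)CC2)ccc1-n1cnc(C)n1` – 110 mL.min-1.g-1

All three compounds share the same core and were tested in an ADME assay on microsomes from liver (Rattus norvegicus) for metabolic stability, read by LC-MS; on this read-out lower numbers stand for slow clearance and higher numbers for fast clearance. Compound 1 gives 77 mL.min-1.g-1 in this assay, the second highest of the three numbers. Its nearest neighbour is compound 3, whose number is slightly higher, but that gap lies within the usual scatter, so the two cannot be told apart. Compound 2 is furthest away, with a much lower number, a gap that is well beyond the scatter.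

Compound 4 `COc1cc(N2CCN(C(=O)Cn3ccc4ccccc43)CC2)ccc1-c1cnc(C)o1` differs from compound 1 in one place: 1H-indol-1-yl in place of 1H-indazol-1-yl on a saturated chain carbon bound to a carbonyl carbon. Going by the values given here, no pair of measured compounds shows this same change, so there is no measured step to lean on, and the expectation rests on compound 1 alone, with its value of 77 mL.min-1.g-1 as the anchor.

A modest rise in clearance is expected, a 1.4-fold higher number from compound 1 to compound 4 (0.15 log units; within the scatter), a step that sits near the edge of the scatter rather than clearly beyond it.

Compound 4 is therefore estimated at 110 mL.min-1.g-1 in this assay, with a likely range from 45 mL.min-1.g-1 to 250 mL.min-1.g-1.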

Compound 4, intrinsic clearance in microsomes: 140 mL.min-1.g-1
Compound 4: middle estimate off by 1.3-fold (0.10 log units), on the low side; low and high end bracket the measured number.
By their numbers in this assay, from the lowest: compound 2; then compounds 1, 3 and 4 (each within the scatter of the next).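

Going by these compounds alone, replacing 1H-indazol-1-yl with 1H-indol-1-yl on a saturated chain carbon bound to a carbonyl carbon gives a 1.8-fold higher number from compound 1 to compound 4 (0.26 log units; within the scatter), the first direct reading of a single change at this position in this assay. Compounds 1 and 4 therefore cannot be told apart on this read-out, which shows that replacing a nitrogen of the five-membered aromatic ring with carbon, with one hydrogen-bond acceptor fewer counted on the group, leaves the number within the scatter for this pair. Nothing measured here bears on what lies behind this result.

Within the data shown here, no single-place step links compound 2, at 7 mL.min-1.g-1, to compound 1 or compound 4, so these compounds do not show which part of its structure goes with its separate number. Going by these compounds, it also remains open how this assay would respond to a different kind of group at this position, such as a carboxylic acid or an amine in place of 1H-indol-1-yl, or to a trifluoromethyl group added to the 1H-indol-1-yl of compound 4.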